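The compounds below may be only part of what the source reports. "The series", "measured", "known", "first", "only" and "open" are said of these compounds alone.

Of the compounds shown here, three have been tested in a functional assay on A549 cells (Homo sapiens) for antiproliferative activity, read by sulforhodamine B assay, with a stated time of 48 h; a higher number here means a weaker inhibitor of growth, a lower number a stronger inhibitor of growth: compound 1 `COc1ccc(S(=O)(=O)c2ccc3c(/C=C/C(=O)NO)cccc3n2)cc1`, compound 2 `O=C(/C=C/c1cccc(S(=O)(=O)c2ccc3ccccc3n2)c1)NO` and compound 3 `O=C(/C=C/c1ccc(S(=O)(=O)c2ccc3ccccc3n2)cc1)NO`. Compound 1 gives > 10000 nM, which is a limit of the assay and not a number. Compound 2 gives 270 nM, the lower of the two actual numbers. Compound 3 gives 880 nM, and its gap to compound 2 lies beyond the usual scatter.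

The next compound is compound 4 `COc1ccc2nc(S(=O)(=O)c3cccc(/C=C/C(=O)NO)c3)ccc2c1`, which differs from compound 2 in one place: methoxy in place of hydrogen on an aromatic carbon. Among the measured compounds shown here, no measured pair shows this change alone, so any forecast is uncertain. For the measured compounds named here, compound 1, the only tested compound with a methoxy, stands at the limit of > 10000 nM, though its structure differs in other ways too. A small rise in the number is therefore expected, and a change within the scatter would be no surprise. The estimated move is a 1.3-fold higher number from compound 2 to compound 4 (0.11 log units; within the scatter). For compound 4 the expected value is 350 nM, with an estimated range of 100 nM to 1500 nM.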

Compound 4, concentration for 50% growth inhibition: 350 nM
Compound 4: middle estimate and measured number agree at the digits printed, within the range that was stated.
By their numbers in this assay, from the lowest: compounds 2 and 4 (each within the scatter of the next); then compound 3. At a limit, above all of these: compound 1.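

In this assay the step for methoxy in place of hydrogen on an aromatic carbon is a 1.3-fold higher number from compound 2 to compound 4 (0.11 log units; within the scatter) and so counts as no real change. Among the compounds shown here, this is the only pair here that differs in one place, and it shows that this carbon of the fused system, meta to a fused ring and para to a fused ring, can carry a methoxy without a measurable loss of growth inhibition. One group at one carbon is a single observation, so no general rule for this ring follows from it.

On these data alone, whether an amine, a carboxylic acid or a longer chain such as ethoxy would be accepted at this carbon stays open, as does the effect of methoxy on the other carbons of this ring. For the compounds shown here, nothing measured so far gives a reason for this result.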